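Compound 4 and a Swapped Aryl Group

This account rests on a few compounds, and the source may have more. Where it says the series, first, only, none or still open, it means among the compounds named here.

Measured compounds:
- compound 1 `COc1ccccc1/C=C(\C(=O)c1ccc(Cl)cc1)S(=O)(=O)c1ccc(C)cc1`: 1000 nM
- compound 2 `Cc1ccc(S(=O)(=O)/C(=C/c2ccc(C)s2)C(=O)c2ccc(Cl)cc2)cc1`: 50000 nM
- compound 3 `CC(=O)Oc1ccc(/C=C(\C(=O)c2ccc(Cl)cc2)S(=O)(=O)c2ccc(C)cc2)cc1`: 25000 nM

In a functional assay on DU-145 cells (Homo sapiens) for inhibition, read by trypan blue exclusion, with a stated time of 96 h (on this read-out lower numbers stand for stronger inhibition of growth and higher numbers for weaker inhibition of growth), compound 3 gives 25000 nM and belongs to the upper pair of the three numbers. It lies within the scatter of compound 2, and compound 1 lies well below both.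

The next compound, compound 4 `Cc1ccc(S(=O)(=O)/C(=C/c2cc(C)cc(C)c2)C(=O)c2ccc(Cl)cc2)cc1`, differs from compound 3 as follows: 3,5-dimethylphenyl in place of 4-acetoxyphenyl on a double-bonded chain carbon bound to a double-bonded chain carbon. In words, 3,5-dimethylphenyl stands in place of 4-acetoxyphenyl on a double-bonded chain carbon bound to a double-bonded chain carbon.

Two measured steps at this same place are large: a 50-fold higher number from compound 1 to compound 2 (1.70 log units; beyond the scatter) and a 25-fold higher number from compound 1 to compound 3 (1.40 log units; beyond the scatter), both beyond the scatter. Both start from the 2-methoxyphenyl group, which compound 4 does not carry. The third, a 2.0-fold lower number from compound 2 to compound 3 (0.30 log units; within the scatter), lies within the scatter, although it joins two quite unlike groups, and it is the closer guide here. For the measured compounds named here, no measured compound carries 3,5-dimethylphenyl, so the range must stay wide.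

The expected result is a 1.7-fold lower number from compound 3 to compound 4 (0.22 log units; within the scatter), so no change beyond the scatter is anticipated. For compound 4 the estimate is 15000 nM, with an expected range from 2500 nM to 50000 nM.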

Compound 4, concentration for 50% growth inhibition: 1000 nM
Compound 4: middle estimate off by 15-fold (1.18 log units), on the high side, and the stated range ends above it.
By their numbers in this assay, from the lowest: compounds 1 and 4 (each within the scatter of the next); then compounds 3 and 2 (each within the scatter of the next).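

In this assay, the position on a double-bonded chain carbon bound to a double-bonded chain carbon proves more responsive than the closeness of compound 2 and compound 3 had suggested: 3,5-dimethylphenyl gives a 25-fold lower number from compound 3 to compound 4 (1.40 log units; beyond the scatter) and, set against 5-methylthiophen-2-yl, a 50-fold lower number from compound 2 to compound 4 (1.70 log units; beyond the scatter). The low number is also no longer confined to 2-methoxyphenyl, since a group of carbon atoms only, with no hydrogen-bond acceptors, gives no change at the digits printed from compound 1 to compound 4 (within the scatter). No evidence accompanying these compounds accounts for these differences.

The compounds shown leave open whether both methyl groups of 3,5-dimethylphenyl are needed, or whether a single methyl or an unsubstituted phenyl would keep the low number. They also leave open how a phenyl ring carrying an amine or a carboxylic acid would behave at this place.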